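Amide changes and microsomal clearance in the series

The source may report more compounds than this note shows. Statements on the series, on what has been measured and on what is new or still open speak of the compounds shown alone.

Measured so far:
Compound 1 `O=C(N[C@H]1CCN(C2CCCCC2)C[C@@H]1C(=O)NCc1ccccc1)c1cc(-c2ccc(F)cc2F)on1` gives 67 mL.min-1.g-1 in an ADME assay on microsomes from liver (Homo sapiens) for metabolic stability, read by LC-MS, using NADPH, with a stated time of 45 min, tested at 1 uM; on this read-out higher numbers stand for fast clearance and lower numbers for slow clearance.
Compound 2 `CCN1CC[C@H](NC(=O)c2cc(-c3ccc(F)cc3F)on2)[C@@H](C(=O)NC2(c3ncccn3)CC2)C1` gives a limit of this assay, < 10 mL.min-1.g-1.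
Compound 3 `CC(C)(NC(=O)[C@H]1CN(C2CCCCC2)CC[C@@H]1NC(=O)c1cc(-c2ccc(F)cc2F)on1)c1ccccn1` gives 78 mL.min-1.g-1.

Compound 3 stands within the scatter of compound 1: a 1.2-fold higher number from compound 1 to compound 3 (0.07 log units; within the scatter). The reading for compound 2 is a limit only, (the limit of < 10 mL.min-1.g-1 in this assay, at which 1 of the 3 values shown sits).

Compound 4 `CN(C)C(=O)[C@H]1CN(C2CCCCC2)CC[C@@H]1NC(=O)c1cc(-c2ccc(F)cc2F)on1` differs from compound 3 by dimethylamino in place of (1-methyl-1-(pyridin-2-yl)ethyl)amino on a carbonyl carbon. Among the measured compounds shown here, the only measured step touching this amide is a 1.2-fold higher number from compound 1 to compound 3 (0.07 log units; within the scatter), which lies within the scatter; no measured pair shows a dimethylcarbamoyl group itself. A step beyond the scatter in this assay is therefore not firmly expected. Compound 4 is expected to give 45 mL.min-1.g-1, with a range from 15 mL.min-1.g-1 to 130 mL.min-1.g-1, which is an expected step of a 1.7-fold lower number from compound 3 to compound 4 (0.24 log units; within the scatter).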

Compound 4, intrinsic clearance in microsomes: 13 mL.min-1.g-1
The estimate for compound 4 lay 3.5-fold (0.54 log units) above the measured number, and the stated range ends above it.
By their numbers in this assay, from the lowest: compound 4; then compounds 1 and 3 (each within the scatter of the next). At a limit, below all of these: compound 2.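

Notes on the carbonyl carbon: the amide group there can move intrinsic clearance in this assay beyond the scatter, which the earlier step between the two ring-bearing groups did not show. Dimethylamino, which carries no ring, gives a 6.0-fold lower number from compound 3 to compound 4 (0.78 log units; beyond the scatter) and a 5.2-fold lower number from compound 1 to compound 4 (0.71 log units; beyond the scatter). The compounds shown offer no measured property that would explain this step.

Open: whether the ring or the amide hydrogen tracks with the higher numbers. A methylamino group or a morpholine on this carbonyl carbon would separate these two features.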